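A few compounds are considered here, and "the series" means these few. Any claim that something is new, unique, unknown or untested is made for them only; others in the source may bear on it.

Within the series built on the core of compound 2 `COc1cc2c(Nc3nc4ccc(C(=O)Nc5c(C)cc(C)cc5C)cc4s3)ncnc2cc1OCCCN1CCCC1`, the amine at the chain end is the point of change. In a functional assay on HCT-116 cells (Homo sapiens) for cytotoxicity, read by WST assay, with a stated time of 72 h (a higher number here means a weaker inhibitor, a lower number a stronger inhibitor), compound 2 gives 5800 nM, the lowest of the two numbers available. Compound 1 `COc1cc2c(Nc3nc4ccc(C(=O)Nc5c(C)cc(C)cc5C)cc4s3)ncnc2cc1OCCCN1CCCCC1` gives 16900 nM, with a 2.9-fold lower number from compound 1 to compound 2 (0.46 log units; beyond the scatter). Compound 3 `COc1cc2c(Nc3nc4ccc(C(=O)Nc5c(C)cccc5C)cc4s3)ncnc2cc1OCCCN1CCCC1` returns only the limit > 100000 nM in this assay. That limit of > 100000 nM in this assay, at which 1 of the 3 values shown sits, is reached with an at least 17-fold higher number from compound 2 to compound 3 (1.23 log units; beyond the scatter), a change on an aromatic carbon rather than at the amine. Compound 4 `CCN(CC)CCCOc1cc2ncnc(Nc3nc4ccc(C(=O)Nc5c(C)cc(C)cc5C)cc4s3)c2cc1OC` differs from compound 2 by diethylamino in place of pyrrolidin-1-yl on a saturated chain carbon, three bonds along the chain from an oxygen on an aromatic ring. Within the data shown here, only the step between compound 1 and compound 2 bears on this position, and it was modest. Compound 4 is therefore estimated at 8000 nM (range 3000 nM to 25000 nM). This expectation means a 1.4-fold higher number from compound 2 to compound 4 (0.14 log units; within the scatter), a shift likely within scatter.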

Compound 4, half-maximal inhibitory concentration: 7500 nM
Compound 4: middle estimate off by 1.1-fold (0.03 log units), on the high side, and the stated range covers the measured number.
By their numbers in this assay, from the lowest: compounds 2 and 4 (each within the scatter of the next); then compound 1. At a limit, above all of these: compound 3.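

In this assay a ring at the chain end is not required: diethylamino in place of pyrrolidin-1-yl gives a 1.3-fold higher number from compound 2 to compound 4 (0.11 log units; within the scatter). Diethylamino in place of piperidin-1-yl gives a 2.3-fold lower number from compound 1 to compound 4 (0.35 log units; beyond the scatter), so of the three amines shown, only piperidin-1-yl stands apart, with the higher number. No measurement shown gives a reason for these steps.

Still open, going by these compounds, is how a morpholin-4-yl, 4-methylpiperazin-1-yl or dimethylamino group would read at the chain end. Also open, on these data alone, is the effect of a chain longer than propyl.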